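The source may report more compounds than this note shows. Statements on the series, on what has been measured and on what is new or still open speak of the compounds shown alone.

Among the compounds with values here, in an ADME assay on L6 cells (Rattus norvegicus) for cytotoxicity, read by resazurin assay, with a stated time of 72 h (a lower number here means a stronger inhibitor, a higher number a weaker inhibitor), compound 1 `C(=C1/CN2CCC1CC2)\c1ccc(C2OCCO2)cc1` gives 239000 nM and stands as the higher of the two numbers measured so far. Compound 2 `C1=C(c2ccc(OCc3ccccc3)cc2)C2CCN1CC2` gives 47200 nM as the lower number, a gap beyond the scatter. Compound 3 `C(=C1CN2CCC1CC2)c1ccc(C2OCCO2)cc1` is still unmeasured. It has the same atoms and bonds as compound 1, and the two compounds have the same atoms and bonds; at least one stereo element is drawn with a configuration in one of them and without one in the other: 1 of 3 stereo elements differ; a double bond is drawn E in compound 1 and without a configuration in compound 3 is the whole difference. Within the data shown here, no measured pair shows such a change, but compound 3 is expected to sit near compound 1 at 239000 nM with no step beyond the scatter in this assay here. The expected step is a 1.0-fold lower number from compound 1 to compound 3 (0.02 log units; within the scatter) and stays small. Compound 3 is estimated at 230000 nM with 110000 nM as the lower end and 400000 nM as the upper end.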

Compound 3, half-maximal inhibitory concentration: 212000 nM
Estimate against measurement, compound 3: 1.1-fold (0.04 log units) above; low and high end bracket the measured number.
By their numbers in this assay, from the lowest: compound 2; then compounds 3 and 1 (each within the scatter of the next).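

Within the data shown here, this is the first pair that differs in only one place, and in this assay it gives a 1.1-fold lower number from compound 1 to compound 3 (0.05 log units; within the scatter), so the two numbers cannot be told apart. A defined double-bond configuration therefore brings no visible gain or loss at this position here. The only difference between the two compounds is one of drawing: the fact that one of compounds 1 and 3 is drawn with a defined configuration and the other without, at the place where they differ.

On these data alone, whether compound 3 is a single form or a mixture stays open, so the effect of the opposite double-bond configuration is unknown. Also open, as far as these compounds go, is how an amine or a carboxylic acid on the shared core would shift the number.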